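The compounds below may be only part of what the source reports. "The series", "measured", "known", "first", "only" and "open" are said of these compounds alone.

Measured compounds:
- Compound 1 `CCc1cc(C)c(C(=O)N=C(N)N)cc1S(C)(=O)=O` — in a functional assay for inhibition of sodium/hydrogen exchanger (Oryctolagus cuniculus) (a lower number here means a stronger inhibitor, a higher number a weaker inhibitor), compound 1 gives 4.8 nM
- Compound 2 `CSc1cc(C)c(C(=O)N=C(N)N)cc1S(C)(=O)=O` — in this assay compound 2 gives 6 nM
- Compound 3 `Cc1cc(-n2ccnc2C)c(S(C)(=O)=O)cc1C(=O)N=C(N)N` — in this assay compound 3 gives 29 nM

Compound 3 stands highest of the three. Its nearest neighbour is compound 2, a 4.8-fold higher number from compound 2 to compound 3 (0.68 log units; beyond the scatter), and its furthest is compound 1, a 6.0-fold higher number from compound 1 to compound 3 (0.78 log units; beyond the scatter). Compounds 1 and 2 sit close to each other, a 1.3-fold higher number from compound 1 to compound 2 (0.10 log units; within the scatter).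

Compound 4 `Cc1cc(-n2ccc(=O)cc2)c(S(C)(=O)=O)cc1C(=O)N=C(N)N` differs from compound 3 in one place: a group of 7 heavy atoms (5 carbon, 1 nitrogen, 1 oxygen; one six-membered aromatic ring with 1 hetero atom) in place of a group of 6 heavy atoms (4 carbon, 2 nitrogen; one five-membered aromatic ring with 2 hetero atoms), on an aromatic carbon

The measured steps that bear on this change are those leading into compound 3, a 6.0-fold higher number from compound 1 to compound 3 (0.78 log units; beyond the scatter) and a 4.8-fold higher number from compound 2 to compound 3 (0.68 log units; beyond the scatter), both modest and both beyond the scatter. Each replaces a small open chain with a ring on that aromatic carbon. Going by the values given here, no measured step exchanges one ring for another ring at this position, so there is no direct precedent for the move from compound 3 to compound 4. Since both rings are aromatic and both are counted with two hydrogen-bond acceptors and no donors, compound 4 is expected to sit near compound 3, with a 1.2-fold higher number from compound 3 to compound 4 (0.08 log units; within the scatter) unlikely to go beyond the scatter. In this assay compound 4 is therefore estimated at 35 nM, within a range of 12 nM to 110 nM.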

Compound 4, half-maximal inhibitory concentration: 75 nM
For compound 4 the middle estimate is 2.1-fold (0.33 log units) below the measured one; the measured number falls inside the stated range.
By their numbers in this assay, from the lowest: compounds 1 and 2 (each within the scatter of the next); then compound 3; then compound 4.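

In this assay, exchanging one aromatic ring for another on this aromatic carbon has a measurable effect even though the two groups have the same counts of hydrogen-bond donors and acceptors: the six-membered ring gives a 2.6-fold higher number from compound 3 to compound 4 (0.41 log units; beyond the scatter), a modest step beyond the scatter, so the identity of the ring matters and not only its presence. Measured from the two open-chain groups, the change to this ring is large, with a 13-fold higher number from compound 2 to compound 4 (1.10 log units; beyond the scatter) and a 16-fold higher number from compound 1 to compound 4 (1.19 log units; beyond the scatter), whereas the steps to the 2-methyl-1H-imidazol-1-yl group were modest. Nothing available bears on why the six-membered ring gives the higher number.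

From the compounds shown here alone, it remains open where a phenyl ring, a morpholine ring or a simple amine on this carbon would fall relative to these compounds. The compounds shown also leave open whether the methyl group on the imidazole ring contributes to the value of compound 3.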